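From 4-fluorophenyl to (pyridin-2-yl)oxy on a saturated ring carbon

The source may hold more compounds than are shown below. What is called first, only, known or untested is meant among the compounds shown, and "the series" means these compounds.

In an ADME assay on cells (Peritoneal macrophage cell, Mus musculus) for cytotoxicity, read by fluorescence and resazurin assay, with a stated time of 3 days (on this read-out higher numbers stand for lower toxicity in this test and lower numbers for higher toxicity in this test), two compounds have been read so far, and neither returned a number. Compound 1 (`CC(C)Oc1cc(C(=O)Nc2cc(-c3ccccn3)n[nH]2)cc(C(=O)N2CCCC2)c1`) gave only a limit (> 40300 nM). Compound 2 (`O=C(Nc1cc(-c2ccccn2)n[nH]1)N1CCC(c2ccc(F)cc2)CC1`) also gave only a limit (> 64000 nM). Going by the values given here, compound 2 therefore has no exact position on this scale, and the only other value shown is a limit too. Compound 3 (`O=C(Nc1cc(-c2ccccn2)n[nH]1)N1CCC(Oc2ccccn2)CC1`) carries (pyridin-2-yl)oxy in place of 4-fluorophenyl on a saturated ring carbon. Among the compounds with values here, no step between measured compounds is available as a guide. That leaves the limit of compound 2 (> 64000 nM) as the anchor for the expectation. The expected step (an at least 1.0-fold lower number from compound 2 to compound 3 (0.02 log units; that floor lies within the scatter)) stays within the usual scatter, with neither direction favoured. Compound 3 is estimated at about 60000 nM within an expected range of 30000 nM to 100000 nM and may well turn out to be only a limit.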

Compound 3, half-maximal cytotoxic concentration: > 64000 nM
Compound 3 ended at the assay's limit; the forecaster's own chance of this, stated with the estimate: 80%; at least 1.0-fold (0.02 log units) between middle value and limit.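

In this assay, going by these compounds alone, compound 2 and compound 3 both ended at a limit of the assay, so no step between them can be read. The compounds shown leave open at what concentration, if any, either compound would become toxic to these cells.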